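Swapping the aminophenyl for a propyl chain

A few compounds are considered here, and "the series" means these few. Any claim that something is new, unique, unknown or untested is made for them only; others in the source may bear on it.

Measured so far in an ADME assay on L929 cells (Mus musculus) for cytotoxicity, read by resazurin assay, with a stated time of 72 h; on this read-out higher numbers stand for weaker inhibition and lower numbers for stronger inhibition:
- compound 1, `CCc1ccc(C(=O)c2ccn(-c3ccc4c(c3)B(O)OC4)c2)cc1`: > 10 ug/mL
- compound 2, `NCc1ccc(C(=O)c2ccn(-c3ccc4c(c3)B(O)OC4)c2)cc1`: > 10 ug/mL
- compound 3, `Nc1ccc(C(=O)c2ccn(-c3ccc4c(c3)B(O)OC4)c2)cc1`: 3.9 ug/mL

Compound 3 stands apart as the only one of the three with an actual number in this assay, giving 3.9 ug/mL. For compound 1 the value > 10 ug/mL is a limit of this assay, not a number. For compound 2 the value > 10 ug/mL is likewise a limit. Among the three, compound 3 therefore shows the strongest inhibition on the numbers shown.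

Compound 4, `CCCC(=O)c1ccn(-c2ccc3c(c2)B(O)OC3)c1`, differs from compound 3 in one place: propyl in place of 4-aminophenyl on a carbonyl carbon. The measured steps that bear on this are an at least 2.5-fold lower number from compound 1 to compound 3 (0.40 log units; beyond the scatter) and an at least 2.5-fold lower number from compound 2 to compound 3 (0.40 log units; beyond the scatter), both ending at compound 3; the step in the other direction, away from the aromatic amino group, is thus the one being followed here. Going from compound 3 to compound 4 is expected to reverse that, with a step of a 2.6-fold higher number from compound 3 to compound 4 (0.41 log units; beyond the scatter) in this assay. The estimate for compound 4 in this assay is 10 ug/mL, within a range from 3.5 ug/mL to 30 ug/mL, and it may well be reported only as a limit, as seen in the limit of > 10 ug/mL in this assay, at which 2 of the 3 values shown sit.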

Compound 4, half-maximal inhibitory concentration: > 10 ug/mL
Compound 4: a limit, no number (the forecaster's own chance of this, stated with the estimate: 55%); the middle value lies on the limit itself.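

In this assay, compound 4 gives > 10 ug/mL, which is a limit and not a number. Among these compounds, replacing the 4-aminophenyl on the carbonyl carbon with propyl gives an at least 2.5-fold higher number from compound 3 to compound 4 (0.40 log units; beyond the scatter), the first measured step at this position to remove the ring altogether. The earlier compounds shown here all kept a substituted phenyl here, but now a chain with no ring also reaches the limit, leaving compound 3 as the only one of the four with a number, and the change of the ring's substituent and the loss of the ring end at the same limit: the limit of > 10 ug/mL in this assay, at which 3 of the 4 values shown sit.

The steps from compound 1 to compound 4 and from compound 2 to compound 4 cannot be read, with limits at both ends of each. Also open, from the compounds shown here alone, is whether a 4-hydroxyphenyl, or a butyl chain ending in an amine, on the same carbonyl carbon would give a number at all.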